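Sulfonyl-linked thiazolone core: swapping phenyl for anilino

This account rests on a few compounds, and the source may have more. Where it says the series, first, only, none or still open, it means among the compounds named here.

Measured so far:
- compound 1, `CN(C)CCn1c(=O)sc2cc(S(=O)(=O)c3ccccc3)ccc21`: 16%
- compound 2, `O=c1sc2cc(S(=O)(=O)c3ccccc3)ccc2n1CCN1CCCCC1`: 11%
- compound 3, `CN(C)CCn1c(=O)sc2cc(NS(=O)(=O)c3ccccc3)ccc21`: 5%

All three compounds were tested in an assay on HEK293 cells for displacement of a labelled ligand from 5-hydroxytryptamine receptor 6 (Homo sapiens), read by radioligand binding, with a stated time of 60 min, tested at 100 nM; a lower number here means less inhibition, a higher number more inhibition at the concentration tested (going by the name of the read-out). Compound 1 gives the highest of the three numbers, at 16%. Compound 2 sits closest, and the step of a number 5 percentage points lower from compound 1 to compound 2 (within the scatter) is within the scatter, so these two cannot be told apart. Within the data shown here, compound 3 gives 5%, a gap from compound 1 that lies beyond the scatter; no single step connects these two, so only the two values themselves can be compared.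

Compound 4, `CN(C)CCn1c(=O)sc2cc(S(=O)(=O)Nc3ccccc3)ccc21`, is not yet measured. It differs from compound 1 as anilino in place of phenyl on a sulfonyl sulfur. Among the measured compounds shown here, the only measured step, from compound 1 to compound 2, touches the amine end of the chain, not the sulfonyl sulfur, so it says nothing directly about this change. Compound 3 shows that altering the link at the sulfonyl can give a lower number, but it is not the same change. Compound 4 is therefore expected to give a number no higher than compound 1, with a likely step a number 6 percentage points lower from compound 1 to compound 4 (within the scatter), and its value in this assay is estimated at 10%, within 0% to 25%.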

Compound 4, a percentage reported as inhibition, at one concentration (the size of the read-out at that concentration, not a potency): 21%
Beside the measured number, compound 4's estimate is 11 percentage points below it; the measured number falls inside the stated range.
By their numbers in this assay, from the lowest: compounds 3, 2, 1 and 4 (each within the scatter of the next, the first and the last beyond it).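

Anilino in place of phenyl on a sulfonyl sulfur gives a number 5 percentage points higher from compound 1 to compound 4 (within the scatter) in this assay and is the first direct reading of a change at this sulfur, as the earlier step touched only the amine end of the chain. The swap brings in a nitrogen and a hydrogen-bond donor, yet this single concentration does not tell compound 1 and compound 4 apart, so the result gives no sign that the change matters for this read-out. No measurement shown here offers an explanation for this result.

Still open, on these data alone, is whether a methyl group on the anilino nitrogen, or a chlorine or methoxy group on the anilino ring, would move the number beyond the usual scatter of this assay when compared with compound 4. Also open, as far as these compounds go, is whether piperidin-1-yl in place of dimethylamino on the chain would behave the same way with anilino on the sulfonyl sulfur as it does with phenyl there.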